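The compounds below may be only part of what the source reports. "The series", "measured", "known", "first", "only" and "open" are said of these compounds alone.

Working notes on the series: the shared core stays fixed, and the group on the side-chain amine nitrogen varies. In a functional assay on MCF7 cells (Homo sapiens) for antiproliferative activity (on this read-out lower numbers stand for stronger inhibition and higher numbers for weaker inhibition), compound 1 `CC(C)=CCc1cc(C(=O)Nc2cc3ccc(OCCCNCC(C)C)c(C)c3oc2=O)ccc1O`, with isobutyl on that nitrogen, gives 1320 nM. Compound 2 `CC(C)=CCc1cc(C(=O)Nc2cc3ccc(OCCCNCC(=O)O)c(C)c3oc2=O)ccc1O`, with carboxymethyl there, gives 18100 nM, which is a 14-fold higher number from compound 1 to compound 2 (1.14 log units; beyond the scatter). Compound 3 `CC(C)=CCc1cc(C(=O)Nc2cc3ccc(OCCCNc4ccccc4)c(C)c3oc2=O)ccc1O`, with phenyl on the nitrogen, reads > 50000 nM, and this is a limit of the assay and not a number. Its standing is fixed only by the limit of > 50000 nM in this assay, at which 1 of the 3 values shown sits.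

Compound 4 `CC(C)=CCc1cc(C(=O)Nc2cc3ccc(OCCCNC(C)(C)c4ccccc4)c(C)c3oc2=O)ccc1O` changes that group: 1-methyl-1-phenylethyl in place of phenyl on an amine nitrogen. In words, 1-methyl-1-phenylethyl stands in place of phenyl on an amine nitrogen, so anilino becomes (1-methyl-1-phenylethyl)amino. Among the compounds with values here, two measured steps bear on this change: an at least 37-fold higher number from compound 1 to compound 3 (1.57 log units; beyond the scatter), and an at least 2.7-fold higher number from compound 2 to compound 3 (0.44 log units; beyond the scatter). Neither contains the new group, so the read-across is loose, and the range is kept wide. On the strength of these two steps, a large move to a lower number is expected in this assay, and the expected change is an at least 8.3-fold lower number from compound 3 to compound 4 (0.92 log units; beyond the scatter). For compound 4 the estimate is 6000 nM, with an expected range of 1200 nM to 30000 nM.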

Compound 4, half-maximal inhibitory concentration: 1070 nM
For compound 4 the middle estimate is 5.6-fold (0.75 log units) above the measured one; measured number outside the range, below it.
By their numbers in this assay, from the lowest: compounds 4 and 1 (each within the scatter of the next); then compound 2. At a limit, above all of these: compound 3.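

In this assay, a phenyl ring in this group does not by itself go with the weak reading: 1-methyl-1-phenylethyl in place of phenyl on the amine nitrogen keeps the six-membered aromatic ring, turns anilino into (1-methyl-1-phenylethyl)amino, and gives an at least 46-fold lower number from compound 3 to compound 4 (1.66 log units; beyond the scatter). The size of that step is bounded from one side only, as compound 3 stands at a limit of the assay and not at a number: the limit of > 50000 nM in this assay, at which 1 of the 4 values shown sits. The same group gives a 17-fold lower number from compound 2 to compound 4 (1.23 log units; beyond the scatter), while against isobutyl it gives a 1.2-fold lower number from compound 1 to compound 4 (0.09 log units; within the scatter), so on this nitrogen an all-carbon group with the ring and one without it read alike, and both stand apart from carboxymethyl.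

Still open, from the compounds shown here alone, is whether the ring or the branched carbon carries the gain over anilino, a question that a benzyl or a cyclohexyl group on the same nitrogen would address. Also open, going by these compounds, is how far this tolerance extends, for instance to a tertiary amine or to a longer chain between the ring and the nitrogen.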